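From 3-methoxyphenyl to 2-bromophenyl on a shared core

The source may hold more compounds than are shown below. What is called first, only, known or untested is meant among the compounds shown, and "the series" means these compounds.

Compound 1 `O=C(CN1CCN(C(=O)c2ccccc2)CC1)N1CCN(CCCc2c[nH]c3ccc(F)cc23)CC1` gives 148000 nM
Compound 2 `O=C(CN1CCN(C(=O)c2ccc(F)cc2)CC1)N1CCN(CCCc2c[nH]c3ccc(F)cc23)CC1` gives 102000 nM
Compound 3 `COc1cccc(C(=O)N2CCN(CC(=O)N3CCN(CCCc4c[nH]c5ccc(F)cc45)CC3)CC2)c1` gives 87100 nM

These values come from an ADME assay on HEK293 cells (Homo sapiens) for cytotoxicity, read by MTT assay, with a stated time of 72 h (on this read-out higher numbers stand for weaker inhibition and lower numbers for stronger inhibition), and compound 3 lies within the usual scatter of both other compounds. Compound 4 `O=C(CN1CCN(C(=O)c2ccccc2Br)CC1)N1CCN(CCCc2c[nH]c3ccc(F)cc23)CC1` has not been measured yet. Its difference from compound 3 2-bromophenyl in place of 3-methoxyphenyl on a carbonyl carbon puts 2-bromophenyl in place of 3-methoxyphenyl on a carbonyl carbon. Three measured steps change the group at that same place: a 1.5-fold lower number from compound 1 to compound 2 (0.16 log units; within the scatter) and a 1.7-fold lower number from compound 1 to compound 3 (0.23 log units; within the scatter) and a 1.2-fold lower number from compound 2 to compound 3 (0.07 log units; within the scatter) all stay within the scatter. None of them involves bromine, so the evidence is indirect. In this assay the expected step is a 1.1-fold higher number from compound 3 to compound 4 (0.04 log units; within the scatter) and thus none beyond the scatter, in either direction. The estimate for compound 4 is 95000 nM with 45000 nM to 190000 nM as its expected range.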

Compound 4, half-maximal inhibitory concentration: 77100 nM
For compound 4 the middle estimate is 1.2-fold (0.09 log units) above the measured one, and the stated range covers the measured number.
By their numbers in this assay, from the lowest: compounds 4, 3, 2 and 1 (each within the scatter of the next).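

Bromine now appears at the position on the carbonyl carbon, and in this assay the number barely shifts: the data show a 1.1-fold lower number from compound 3 to compound 4 (0.05 log units; within the scatter) and a 1.3-fold lower number from compound 2 to compound 4 (0.12 log units; within the scatter) and a 1.9-fold lower number from compound 1 to compound 4 (0.28 log units; within the scatter), all within the scatter. The phenyl, 4-fluorophenyl, 3-methoxyphenyl and 2-bromophenyl compounds therefore cannot be told apart in this assay. Nothing available here gives a reason for this result.

From the compounds shown here alone, whether an amine or a carboxylic acid on that aromatic ring would move the number beyond the scatter remains open.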